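The compounds below may be only part of what the source reports. "The series", "measured", "known", "first", "only" and "open" are said of these compounds alone.

Measured compounds:
compound 1 `Cc1ccc(NC(=S)NC(=O)c2cn(-c3ccccc3)nc2-c2ccc(Cl)cc2)cc1` with 5980 nM
compound 2 `COc1ccc(-c2nn(-c3ccccc3)cc2C(=O)NC(=S)Nc2ccc(F)cc2)cc1` with 4990 nM

Both numbers come from a functional assay on MCF7 cells (Homo sapiens) for inhibition, read by CCK-8 assay, with a stated time of 48 h; on this read-out lower numbers stand for stronger inhibition and higher numbers for weaker inhibition. Compound 1 and compound 2 differ in two places at once, on the ring attached to the shared core and on the ring attached to the thiourea, so their comparison does not isolate a single change. Their two values lie within the usual scatter of each other, and compound 2 cannot be set apart from compound 1 on this basis.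

Compound 3 `O=C(NC(=S)Nc1ccc(F)cc1)c1cn(-c2ccccc2)nc1-c1ccc(Cl)cc1` has not yet been measured. It keeps the ring of compound 2 on the thiourea side and differs in one place: chloro in place of methoxy on an aromatic carbon. The same chloro-bearing ring is already present in compound 1, whose value in this assay sits close to that of compound 2. Among the measured compounds shown here, no measured pair isolates this change, so the step is expected to be small, without a clear direction, and to stay within the scatter, as a 1.1-fold higher number from compound 2 to compound 3 (0.04 log units; within the scatter) expresses. Compound 3 is accordingly estimated at 5500 nM, within a range from 2500 nM to 12000 nM.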

Compound 3, half-maximal inhibitory concentration: 5990 nM
Estimate against measurement, compound 3: 1.1-fold (0.04 log units) below; measured number inside the range.
By their numbers in this assay, from the lowest: compounds 2, 1 and 3 (each within the scatter of the next).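

In this assay, chloro in place of methoxy on an aromatic carbon, para to a large group, gives a 1.2-fold higher number from compound 2 to compound 3 (0.08 log units; within the scatter) at this position, so the change from 4-methoxyphenyl to 4-chlorophenyl can now be read on its own and cannot be told apart from no change at all. The ring on the thiourea side can now be read on its own too: fluoro in place of methyl on an aromatic carbon gives a 1.0-fold higher number from compound 1 to compound 3 (0.00 log units; within the scatter) and also cannot be told apart from no change, so the two single changes shown leave all three compounds indistinguishable in this test. No further data are available to explain why these values stay together.

Among the compounds shown here, each position has so far been probed with only this one exchange of groups, so it remains open whether a different kind of group there, such as an amine or a carboxylic acid, would shift the number beyond the scatter. As far as these compounds go, a longer chain in place of the methoxy, such as butoxy, is equally open, as is whether either change would behave the same way on a different ring of the shared core.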